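A few compounds are considered here, and "the series" means these few. Any claim that something is new, unique, unknown or untested is made for them only; others in the source may bear on it.

Compound 1 is `COC(=O)c1ccc(-c2cccc(NC(=O)C(Cl)Cl)c2)cc1`. In a functional assay on KB 3-1 cells (Homo sapiens) for cytotoxicity, read by MTT assay, with a stated time of 68 h (a lower number here means a stronger inhibitor, a higher number a weaker inhibitor), compound 1 reaches only the limit of the assay, > 50000 nM.
Compound 2 is `Nc1cccc(-c2cccc(NC(=O)C(Cl)Cl)c2)c1`. In this assay compound 2 gives 26100 nM.
Compound 3 is `Cc1ccc(-c2cccc(NC(=O)C(Cl)Cl)c2)cc1`. In this assay compound 3 likewise reaches only the limit of the assay, > 50000 nM.

Within the data shown here, compound 3 therefore stands not at a number but at the limit of > 50000 nM in this assay, at which 2 of the 3 values shown sit, and so the one step that touches it, a step that the two limits leave unreadable from compound 1 to compound 3, cannot be read as a size. Of the three compounds, only compound 2 gives a figure, and that figure is a weak one.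

Compound 4 is `O=C(Nc1cccc(-c2ccccc2)c1)C(Cl)Cl`. It differs from compound 3 by hydrogen in place of methyl on an aromatic carbon. Among the measured compounds shown here, no measured step resolves what such a change does here, since the only step that reaches compound 3 runs between two limits. What the shared core has shown so far is weak inhibition in this assay for every member, with two of three at the limit.

Compound 4 is thus expected to stay in the same weak region, with the step of an at least 1.2-fold lower number from compound 3 to compound 4 (0.09 log units; that floor lies within the scatter) expected to lie within the scatter, and its value in this assay is estimated at 40000 nM, between 10000 nM and 150000 nM, with a fair chance that only a limit is recorded.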

Compound 4, half-maximal inhibitory concentration: 46800 nM
Compound 4: middle estimate off by 1.2-fold (0.07 log units), on the low side, and the stated range covers the measured number.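

Compound 4, with hydrogen on this aromatic carbon, gives a number in this assay where compound 1 and compound 3 gave only limits, so this position now has a measured reference point. Hydrogen in place of methyl gives an at least 1.0-fold lower number from compound 3 to compound 4 (0.02 log units; that floor lies within the scatter), and hydrogen in place of methoxycarbonyl gives an at least 1.0-fold lower number from compound 1 to compound 4 (0.02 log units; that floor lies within the scatter); these are floors only, and neither shows that removing the group changes the result beyond the scatter. Hydrogen in place of amino gives a 1.8-fold higher number from compound 2 to compound 4 (0.25 log units; within the scatter), so the two compounds with actual figures cannot be told apart, and the amino group is not shown to add anything over hydrogen, while the other two compounds remain at a limit: the limit of > 50000 nM in this assay, at which 2 of the 4 values shown sit.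

The compounds shown leave open whether any group on this aromatic carbon, such as a carboxylic acid, a hydroxyl or a longer chain, can bring the shared core out of this weak region. They also leave open how the number would respond to a change on the other side of the core, for instance a monochloroacetyl or a trifluoroacetyl group in place of the dichloroacetyl group.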